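Replacing Fluoro With Benzyl at the Chain Carbon

The compounds below may be only part of what the source reports. "The series", "measured", "known", "first", "only" and "open" are said of these compounds alone.

Compound 1, `CCCCCCCCCCCCn1nnc(C(C(=O)Nc2c(OC)cc(OC)cc2OC)c2ccc(N(C)C)cc2)n1`: 659 nM in an assay on liver for inhibition of sterol O-acyltransferase 1 (Rattus norvegicus), using microsomes; a higher number here means a weaker inhibitor, a lower number a stronger inhibitor
Compound 2, `CCCCCCCCCCCCn1nnc(C(F)C(=O)Nc2c(OC)cc(OC)cc2OC)n1`: 1760 nM in this assay

Within the data shown here, compound 2 stands at the highest of the two numbers measured so far. Among the measured compounds shown here, its only neighbour is compound 1, and the single step between them, a 2.7-fold higher number from compound 1 to compound 2 (0.43 log units; beyond the scatter), is modest but beyond the scatter; it replaced the 4-(dimethylamino)phenyl group with fluoro on the saturated chain carbon bound to an aromatic carbon and a carbonyl carbon, and the number rose.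

Compound 3, `CCCCCCCCCCCCn1nnc(C(Cc2ccccc2)C(=O)Nc2c(OC)cc(OC)cc2OC)n1`, is not yet measured. It differs from compound 2 by benzyl in place of fluoro on a saturated chain carbon bound to an aromatic carbon and a carbonyl carbon. For the measured compounds named here, the only measured step that bears on this change is a 2.7-fold higher number from compound 1 to compound 2 (0.43 log units; beyond the scatter), in which a group containing a six-membered aromatic ring gave way to fluoro at the same place and the inhibitor weakened. Compound 3 reverses that direction by putting an aromatic ring back, so a step downward in this assay of roughly comparable size is expected, though the group entering is not the same as the one that left. Compound 3 is therefore estimated at 700 nM in this assay, within a range from 250 nM to 2000 nM, an expected step of a 2.5-fold lower number from compound 2 to compound 3 (0.40 log units; beyond the scatter).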

Compound 3, half-maximal inhibitory concentration: 490 nM
The estimate for compound 3 lay 1.4-fold (0.15 log units) above the measured number; the measured number falls inside the stated range.
By their numbers in this assay, from the lowest: compounds 3 and 1 (each within the scatter of the next); then compound 2.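

In this assay, benzyl in place of fluoro on the saturated chain carbon bound to an aromatic carbon and a carbonyl carbon gives a clear drop (a 3.6-fold lower number from compound 2 to compound 3 (0.56 log units; beyond the scatter)), so a second group carrying a six-membered aromatic ring, different from 4-(dimethylamino)phenyl, also stands below fluoro at this place. The comparison of the two aromatic groups adds what the earlier pair could not show: benzyl and 4-(dimethylamino)phenyl are not separated here (a 1.3-fold lower number from compound 1 to compound 3 (0.13 log units; within the scatter)), so the dimethylamino group is not needed for a number in this range, and the ring need not be bound directly to the chain carbon. Nothing available accounts for these differences in terms of how either group acts.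

The compounds leave open whether the aromatic ring matters at all, or whether a saturated ring such as cyclohexyl or a plain chain such as butyl at this carbon would match benzyl rather than fluoro. They also leave open how a carboxylic acid or a methoxy group on the benzyl ring, or a longer link such as phenethyl, would fare in this assay at this same place.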